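Adding a hydroxypropyl chain to compound 3

This account rests on a few compounds, and the source may have more. Where it says the series, first, only, none or still open, it means among the compounds named here.

Three compounds have been measured in an assay on HepG2 cells for antagonist activity at Bile acid receptor (Homo sapiens), read by a luciferase reporter; on this read-out lower numbers stand for stronger inhibition and higher numbers for weaker inhibition:

compound 1, `c1ccc2cc(-c3noc(C4CCNCC4)n3)ccc2c1`, gives 580 nM
compound 2, `OCCCCN1CCC(c2nc(-c3ccc4ccccc4c3)no2)CC1`, gives 1170 nM
compound 3, `c1ccc2cc(-c3noc([C@@H]4CCCCN4)n3)ccc2c1`, gives 127 nM

Compound 3 stands lowest of the three numbers in this assay: its nearest neighbour is compound 1, with a 4.6-fold lower number from compound 1 to compound 3 (0.66 log units; beyond the scatter), and compound 2 lies further off. Compound 4, `OCCCN1CCCC[C@H]1c1nc(-c2ccc3ccccc3c2)no1`, differs from compound 3 in one place: 3-hydroxypropyl in place of hydrogen on an amine nitrogen in a ring. Among the measured compounds shown here, only one measured step bears on this change. Between compound 1 and compound 2 a 4-hydroxybutyl chain was put on the same kind of ring amine nitrogen, and the result was a 2.0-fold higher number from compound 1 to compound 2 (0.30 log units; within the scatter), a step that stays within the usual scatter. For the measured compounds named here, no measured step shows how the shorter 3-hydroxypropyl chain behaves, nor how such a chain fares on the ring of compound 3, so the expectation rests on that single comparison. In this assay the expected step is therefore estimated as a 1.6-fold higher number from compound 3 to compound 4 (0.20 log units; within the scatter), a small step tending towards a higher number that stays within the scatter. For compound 4 the estimated value in this assay is 200 nM, with a range from 80 nM to 550 nM.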

Compound 4, half-maximal inhibitory concentration: 27000 nM
Beside the measured number, compound 4's estimate is 140-fold (2.13 log units) below it, outside the stated range (above it).
By their numbers in this assay, from the lowest: compound 3; then compounds 1 and 2 (each within the scatter of the next); then compound 4.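

In this assay, among the compounds shown here, the hydrogen on the amine nitrogen of compound 3 turns out to matter far more than the earlier compounds suggested: putting 3-hydroxypropyl there gives a 210-fold higher number from compound 3 to compound 4 (2.33 log units; beyond the scatter) and takes the series to its highest number. The only earlier chain on a ring amine nitrogen, 4-hydroxybutyl, gave a 2.0-fold higher number from compound 1 to compound 2 (0.30 log units; within the scatter) on the piperidin-4-yl ring, so that small step is no guide to the nitrogen of compound 3, which lies next to the ring atom that bears a large group. Nothing measured here accounts for the size of this new step.

As far as these compounds go, it remains open whether any group at all is accepted on this nitrogen; a methyl group or an ethyl chain would show whether even a very small addition brings so large a step. A plain propyl chain without the hydroxyl would separate the effect of the carbon chain from that of its end group, and a 3-hydroxypropyl chain on the ring of compound 1 would test whether the ring attachment decides the outcome.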